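From Chloro to Methylcarbamoyl in Compound 4

The compounds below may be only part of what the source reports. "The series", "measured", "known", "first", "only" and "open" are said of these compounds alone.

Compound 3 `O=S(=O)(Nc1ccc(NS(=O)(=O)c2ccc(Cl)cc2)cc1)c1ccc(F)cc1` reaches only a limit in an assay for inhibition of liver carboxylesterase 1 (Homo sapiens), read by spectrophotometry; on this read-out lower numbers stand for stronger inhibition and higher numbers for weaker inhibition: compound 3 gives > 100000 nM. Compound 1 `Cc1ccc(S(=O)(=O)Nc2ccc(NS(=O)(=O)c3ccc(F)cc3)cc2)cc1` likewise stops at a limit, giving > 100000 nM. Compound 2 `O=S(=O)(Nc1ccc(NS(=O)(=O)c2ccc(F)cc2)cc1)c1ccc(F)cc1` also stops at a limit, with > 100000 nM. The steps a step that the two limits leave unreadable from compound 1 to compound 2, a step that the two limits leave unreadable from compound 1 to compound 3 and a step that the two limits leave unreadable from compound 2 to compound 3 cannot be read because all three values sit at the limit of > 100000 nM in this assay, at which 3 of the 3 values shown sit. Compound 4 `CNC(=O)c1ccc(S(=O)(=O)Nc2ccc(NS(=O)(=O)c3ccc(F)cc3)cc2)cc1` differs from compound 3 by methylcarbamoyl in place of chloro on an aromatic carbon. Going by the values given here, no measured step bears on this change, so the expected step of a number no higher from compound 3 to compound 4 (the limit leaves the size open) is set at none beyond the scatter. Compound 4 is therefore expected to give about 100000 nM in this assay, within 30000 nM to 300000 nM, most likely again reported only as a limit.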

Compound 4, inhibition constant: > 100000 nM
Compound 4 gave a limit, no number (the forecaster's own chance of this, stated with the estimate: 75%); the middle value lies on the limit itself.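

Going by these compounds alone, no step from compound 4 to compound 1, compound 2 or compound 3 can be read in this assay, because each value is only a limit: the limit of > 100000 nM in this assay, at which 4 of the 4 values shown sit.

The compounds shown leave open how any change on the shared core alters inhibition.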